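This account rests on a few compounds, and the source may have more. Where it says the series, first, only, none or still open, it means among the compounds named here.

Measured in an ADME assay on HT-29 cells (Homo sapiens) for cytotoxicity, read by MTT assay, with a stated time of 72 h; on this read-out higher numbers stand for weaker inhibition and lower numbers for stronger inhibition:
- compound 1 `COc1ccc(C2=C(c3cc(OC)c(OC)c(OC)c3)C(=O)C(OC(C)=O)C2)cc1OC(C)C`: > 100 ug/mL (a limit)
- compound 2 `COc1ccc(C2=C(c3cc(OC)c(OC)c(OC)c3)C(=O)C(OC(C)=O)C2)cc1F`: < 1 ug/mL (a limit)
- compound 3 `COc1ccc(C2=C(c3cc(OC)c(OC)c(OC)c3)C(=O)C(O)C2)cc1Cl`: < 1 ug/mL (a limit)

Compound 3 gives < 1 ug/mL, which is a limit and not a number. That places it at the limit of < 1 ug/mL in this assay, at which 2 of the 3 values shown sit.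

Compound 4 `COc1ccc(C2=C(c3cc(OC)c(OC)c(OC)c3)C(=O)C(OC(C)=O)C2)cc1Cl` has not yet been measured. It differs from compound 3 by one change, acetyl in place of hydrogen on an oxygen on a saturated carbon, or hydroxy to acetoxy.

Among the compounds with values here, the only measured step is an at least 100-fold lower number from compound 1 to compound 2 (2.00 log units; beyond the scatter). That step is large, but it is fluoro in place of isopropoxy on an aromatic carbon, and the acetoxy group stays in place throughout, so it does not measure the new change directly.

Compound 1 carries the acetoxy group and gives > 100 ug/mL, a limit, so the group alone does not fix the result. Compound 2 also carries the acetoxy group and gives < 1 ug/mL, again a limit, so no step beyond the scatter is expected in this assay, and no direction is favoured.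

The expected outcome is a step that the limit leaves unreadable from compound 3 to compound 4. For compound 4 the estimated value is 0.5 ug/mL, with an expected range from 0.1 ug/mL to 3 ug/mL.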

Compound 4, half-maximal inhibitory concentration: < 1 ug/mL
Compound 4 gave a limit, no number; the forecaster's own chance of this, stated with the estimate: 80%; the middle value lies beyond the limit too.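

In this assay, replacing the isopropoxy group with chloro gives an at least 100-fold lower number from compound 1 to compound 4 (2.00 log units; beyond the scatter), a large change that matches the one seen for fluoro in place of isopropoxy, an at least 100-fold lower number from compound 1 to compound 2 (2.00 log units; beyond the scatter), with the acetoxy group present throughout. The steps to compound 4 from compound 3 and from compound 2 cannot be read, as both values in each pair are limits and not numbers. What the new result does show is that placing acetyl on the oxygen of compound 3, hydroxy to acetoxy, does not move compound 4 away from the limit shared by most of this small set: the limit of < 1 ug/mL in this assay, at which 3 of the 4 values shown sit.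

As far as these compounds go, how far compound 2, compound 3 and compound 4 each lie beyond that limit stays unknown, so neither hydroxy against acetoxy nor chloro against fluoro can be ranked here. Also open, from the compounds shown here alone, is whether a longer acyl chain, an amine or a carboxylic acid in place of the acetoxy group, on that same saturated carbon, would keep the result at this limit.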